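A Methyl Added Where Both Parents Reached Only Limits

The source may hold more compounds than are shown below. What is called first, only, known or untested is meant among the compounds shown, and "the series" means these compounds.

Compound 1, `Cc1cc(=O)oc2cc(SCc3ccccn3)ccc12`, a limit of > 35200 nM
Compound 2, `CCc1cc(=O)c2ccc(Sc3cccc(Cl)n3)cc2o1`, a limit of > 31400 nM

Two compounds have so far been examined in a functional assay on DU-145 cells (Homo sapiens) for antiproliferative activity, read by sulforhodamine B assay, with a stated time of 72 h (on this read-out lower numbers stand for stronger inhibition of growth and higher numbers for weaker inhibition of growth), and neither gave a number. Compound 1 reached only a limit, > 35200 nM. Compound 2 likewise reached only a limit, > 31400 nM. Compound 2 therefore stands at the limit of > 31400 nM in this assay, at which 1 of the 2 values shown sits. The other recorded result is also a limit, (the limit of > 35200 nM in this assay, at which 1 of the 2 values shown sits), so no ordering between the two compounds can be drawn.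

Compound 3, `CCc1cc(=O)c2ccc(Sc3cccc(Cl)n3)c(C)c2o1`, is the next candidate for this assay. It differs from compound 2 by methyl in place of hydrogen on an aromatic carbon. Among the compounds with values here, no step between measured compounds has been recorded, so nothing anchors the size of this change; with compound 2 at a limit, only an unmeasured weak region is known. The expectation is that compound 3 stays in the same region, and the step from compound 2 to compound 3 is estimated as a step that the limit leaves unreadable from compound 2 to compound 3. Compound 3 is accordingly expected to come in near 40000 nM, within 10000 nM to 120000 nM, most likely again as a limit rather than a number.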

Compound 3, concentration for 50% growth inhibition: > 30100 nM
Compound 3 was reported as a limit; the forecaster's own chance of this, stated with the estimate: 80%; the middle value is on the limit's open side.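

Compound 3 also reached only a limit in this assay, > 30100 nM. Compound 2 is likewise a limit, > 31400 nM, so no step can be read between compound 2 and compound 3. The compounds shown leave open how strongly any of them inhibits growth, and what size of effect, if any, the methyl has.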